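Urea Tail Swap on a Shared Sulfonamide Core

The source may hold more compounds than are shown below. What is called first, only, known or untested is meant among the compounds shown, and "the series" means these compounds.

Three measured compounds share one core and differ only in the tail on the urea. In a functional assay on MCF7 cells (Homo sapiens) for cytotoxicity, read by MTT assay, with a stated time of 72 h (on this read-out lower numbers stand for stronger inhibition and higher numbers for weaker inhibition), compound 1 `CCCNC(=O)Nc1nc2ccc(-c3cnc(OC)c(NS(=O)(=O)c4ccc(F)cc4)c3)cn2n1` gives 360 nM, compound 2 `COc1ncc(-c2ccc3nc(NC(=O)N4CCCC4)nn3c2)cc1NS(=O)(=O)c1ccc(F)cc1` gives 1660 nM, and compound 3 `COc1ncc(-c2ccc3nc(NC(=O)NC4CC4)nn3c2)cc1NS(=O)(=O)c1ccc(F)cc1` gives 300 nM, the lowest of the three; its gap to compound 1 is within the scatter, while a 5.5-fold lower number from compound 2 to compound 3 (0.74 log units; beyond the scatter) is beyond it. Compound 4 `COc1ncc(-c2ccc3nc(NC(=O)NCCN4CCN(C)CC4)nn3c2)cc1NS(=O)(=O)c1ccc(F)cc1` carries 2-(4-methylpiperazin-1-yl)ethyl in place of cyclopropyl on an amide-type nitrogen. Among the compounds with values here, the one step at this same amide-type nitrogen, a 1.2-fold lower number from compound 1 to compound 3 (0.08 log units; within the scatter), lies within the scatter, whereas a 4.6-fold higher number from compound 1 to compound 2 (0.66 log units; beyond the scatter) concerns a different kind of change and is less relevant. The expected step is therefore a 1.4-fold higher number from compound 3 to compound 4 (0.15 log units; within the scatter), within the scatter. Compound 4 is thus estimated at 420 nM, between 150 nM and 1200 nM.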

Compound 4, half-maximal inhibitory concentration: 500 nM
Compound 4: middle estimate off by 1.2-fold (0.08 log units), on the low side, within the range that was stated.
By their numbers in this assay, from the lowest: compounds 3, 1 and 4 (each within the scatter of the next); then compound 2.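

Putting 2-(4-methylpiperazin-1-yl)ethyl in place of cyclopropyl on the amide-type nitrogen gives a 1.7-fold higher number from compound 3 to compound 4 (0.22 log units; within the scatter) in this assay, so a much larger tail with a six-membered ring and two nitrogens is accepted here. Adding 4-methylpiperazin-1-yl to the chain end gives a 1.4-fold higher number from compound 1 to compound 4 (0.14 log units; within the scatter), and the gap to the pyrrolidin-1-yl urea remains, at a 3.3-fold lower number from compound 2 to compound 4 (0.52 log units; beyond the scatter). No measurement is available to explain these steps.

On these data alone, it remains open whether a carboxylic acid or a morpholine on the same ethyl chain would give a similar number.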